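The compounds below may be only part of what the source reports. "The series", "measured", "known", "first", "only" and "open" are said of these compounds alone.

Measured compounds:
compound 1 `COc1cc(/C=C/C(=O)c2sc(Nc3ccc(C)cc3)nc2C)cc(OC)c1OC` — > 25000 nM
compound 2 `Cc1ccccc1Nc1nc(C)c(C(=O)/C=C/c2ccccc2Cl)s1` — > 25000 nM

In a functional assay on NCI-H460 cells (Homo sapiens) for cytotoxicity, read by MTT assay (a higher number here means a weaker inhibitor, a lower number a stronger inhibitor), compound 1 gives > 25000 nM, which is a limit of the assay and not a number. Compound 2 likewise gives > 25000 nM, again a limit. Every value shown sits at the limit of > 25000 nM in this assay, at which 2 of the 2 values shown sit, so compound 1 stands at the edge of what this assay reports, with nothing to rank it against. Compound 3 `COc1cc(/C=C/C(=O)c2sc(Nc3ccc(Cl)cc3)nc2C)cc(OC)c1OC` differs from compound 1 by chloro in place of methyl on an aromatic carbon. For the measured compounds named here, no step between measured compounds exists to guide the estimate, so he expects no change beyond the scatter, a step that the limit leaves unreadable from compound 1 to compound 3. Compound 3 is therefore estimated at 30000 nM, between 8000 nM and 100000 nM.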

Compound 3, half-maximal inhibitory concentration: 22000 nM
Beside the measured number, compound 3's estimate is 1.4-fold (0.13 log units) above it; measured number inside the range.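

For the compounds shown here, compound 3, at 22000 nM in this assay, gives the first reading that is a number rather than a limit, so chloro in place of methyl on this aromatic carbon brings the series just inside the readable range. The change gives an at least 1.1-fold lower number from compound 1 to compound 3 (0.05 log units; that floor lies within the scatter), a floor within the scatter, so it shows no firm gain. The true size of the step stays unknown, and the series still rests largely on the limit: the limit of > 25000 nM in this assay, at which 2 of the 3 values shown sit.

The compounds shown leave open how far the number moves with other groups at this place, such as an amine or a nitrile. They also leave open whether any change at this place gives a step beyond the scatter.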